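This account rests on a few compounds, and the source may have more. Where it says the series, first, only, none or still open, it means among the compounds named here.

Three measured compounds share one core and differ only in the group hanging off the chain that leaves the oxygen. Compound 1 `O=c1[nH]/c(=N\OCCCCc2ccccc2)ccn1[C@@H]1O[C@H](COP(=O)(O)OP(=O)(O)OP(=O)(O)O)[C@@H](O)[C@H]1O` carries a benzyl group at the end of that chain, compound 2 `O=c1[nH]/c(=N\OCCCc2cccc(F)c2)ccn1[C@@H]1O[C@H](COP(=O)(O)OP(=O)(O)OP(=O)(O)O)[C@@H](O)[C@H]1O` a 3-fluorophenyl group, and compound 3 `O=c1[nH]/c(=N\OCCCc2ccc(F)cc2)ccn1[C@@H]1O[C@H](COP(=O)(O)OP(=O)(O)OP(=O)(O)O)[C@@H](O)[C@H]1O` a 4-fluorophenyl group. In a functional assay on 1321-N1 cells for agonist activity at P2Y purinoceptor 4 (Homo sapiens), read by scintillation counting and inositol phosphate accumulation (on this read-out lower numbers stand for an effect already at smaller amounts and higher numbers for an effect only at larger amounts of compound), compound 1 gives 54 nM, compound 2 gives 100 nM, and compound 3 gives 105 nM. The steps between them are small: a 1.9-fold higher number from compound 1 to compound 2 (0.27 log units; within the scatter), a 1.9-fold higher number from compound 1 to compound 3 (0.29 log units; within the scatter), and a 1.1-fold higher number from compound 2 to compound 3 (0.02 log units; within the scatter). Compound 3 thus shows the highest of the three numbers, yet both of its neighbours sit within the scatter of it, so no ordering among the three can be read from these figures.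

Compound 4 `O=c1[nH]/c(=N\OCCCc2ccc(Br)cc2)ccn1[C@@H]1O[C@H](COP(=O)(O)OP(=O)(O)OP(=O)(O)O)[C@@H](O)[C@H]1O` is the next variation. It differs from compound 3 in one place: bromo in place of fluoro on an aromatic carbon. For the measured compounds named here, none of the measured steps swaps one halogen for another; they only move the fluorine or change the chain, and all stayed within the scatter. On that basis, in this assay compound 4 is expected to give 100 nM, with a range from 40 nM to 250 nM. Seen as a step, the expectation reads a 1.1-fold lower number from compound 3 to compound 4 (0.02 log units; within the scatter), which is no change beyond the scatter.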

Compound 4, half-maximal effective concentration: 141 nM
For compound 4 the middle estimate is 1.4-fold (0.15 log units) below the measured one, and the stated range covers the measured number.
By their numbers in this assay, from the lowest: compounds 1, 2, 3 and 4 (each within the scatter of the next, the first and the last beyond it).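

In this assay, the swap of one halogen for another on an aromatic carbon para to a large group gives only a small step (a 1.3-fold higher number from compound 3 to compound 4 (0.13 log units; within the scatter)), so at this place the bromo and fluoro compounds cannot be told apart. For the compounds shown here, the 4-bromophenyl group also cannot be separated from the 3-fluorophenyl group (a 1.4-fold higher number from compound 2 to compound 4 (0.15 log units; within the scatter)), but replacing the benzyl group of compound 1 with it gives the first step in this set to pass beyond the scatter (a 2.6-fold higher number from compound 1 to compound 4 (0.42 log units; beyond the scatter)), although that step is only modest. Nothing available offers a measured explanation for these numbers.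

The aromatic ring in the compounds shown carries only fluoro or bromo, if it carries anything, so it remains open whether a very different group on the same carbon, such as an amine or a carboxylic acid, would stay this close to compound 3. Going by these compounds, it is equally open whether a longer chain would hold the number near that of compound 1 or move it further away.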